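This account rests on a few compounds, and the source may have more. Where it says the series, first, only, none or still open, it means among the compounds named here.

Measured so far:
Compound 1 `Cc1ccccc1-c1nn(Cc2ccc(F)cc2)cc1CNCCN1CCN(C)CC1`. In an ADME assay on Huh-7 cells (Homo sapiens) for cytotoxicity (on this read-out higher numbers stand for lower toxicity in this test and lower numbers for higher toxicity in this test), compound 1 gives > 20000 nM, which is a limit of the assay and not a number.
Compound 2 `CSc1ccc(-n2cc(CNCCN3CCN(C)CC3)c(-c3ccccc3C)n2)cc1`. In this assay compound 2 gives 17000 nM.

Within the data shown here, compound 2 thus holds the only number given in this assay; the other value is a limit, (the limit of > 20000 nM in this assay, at which 1 of the 2 values shown sits). Among the measured compounds shown here, the single measured step, an at least 1.1-fold lower number from compound 1 to compound 2 (0.07 log units; that floor lies within the scatter), starts from that limit, so only a floor is known for it and that floor lies within the scatter.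

Compound 3 `Cc1ccccc1-c1nn(-c2cccc(Cl)c2)cc1CNCCN1CCN(C)CC1` is not yet measured. It differs from compound 2 by 3-chlorophenyl in place of 4-(methylsulfanyl)phenyl on an aromatic nitrogen. For the measured compounds named here, the step from compound 1 to compound 2 also exchanged the group on the aromatic nitrogen of the shared core and is the only measured step that bears on this change; its known size is a floor within the scatter. No step beyond the scatter is therefore expected in this assay from compound 2 to compound 3, with a real chance that compound 3 again reports only a limit. For compound 3 the estimated value is 17000 nM, with a range from 8000 nM to 40000 nM. The expected step is no change at the digits printed from compound 2 to compound 3 (within the scatter).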

Compound 3, half-maximal cytotoxic concentration: 16000 nM
Compound 3: middle estimate off by 1.1-fold (0.03 log units), on the high side; the measured number falls inside the stated range.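

In this assay, among these compounds, a 1.1-fold lower number from compound 2 to compound 3 (0.03 log units; within the scatter) is the first step at this position with a number at both ends, and so the first whose size is known and not only a floor. At this position of the shared core, 3-chlorophenyl and 4-(methylsulfanyl)phenyl cannot be told apart in this read-out, although the exchange replaces a sulfur-bearing group at the 4-position of the phenyl ring with a chlorine at the 3-position. The other new step, an at least 1.2-fold lower number from compound 1 to compound 3 (0.09 log units; that floor lies within the scatter), starts from a limit of the assay and not a number, so the comparison of 3-chlorophenyl with 4-fluorobenzyl yields only a floor, as with the earlier exchange of 4-fluorobenzyl: the limit of > 20000 nM in this assay, at which 1 of the 3 values shown sits.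

As far as these compounds go, the true size of the difference between the directly attached phenyl groups and the 4-fluorobenzyl group therefore stays open, since the floors say nothing about how far that number lies from the limit. Also open, from the compounds shown here alone, is whether a more different group on the aromatic nitrogen, such as a phenyl ring carrying an amine or a carboxylic acid, or a longer chain in place of the ring, would give a step in this assay beyond the scatter.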